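The compounds below may be only part of what the source reports. "The series", "measured", "known", "first", "only" and "open" are said of these compounds alone.

Of the compounds shown here, three have been measured in a functional assay on a cell-free system (plasma) for inhibition of thromboxane A2 receptor (Homo sapiens), read by turbidimetry; on this read-out lower numbers stand for stronger inhibition and higher numbers for weaker inhibition. Compound 1, `O=C(O)COCCCCC1=CCC[C@@H]1NS(=O)(=O)c1ccccc1[N+](=O)[O-]`, gives 1900 nM in this assay. Compound 3, `O=C(O)COCCCCC1=CCC[C@@H]1NS(=O)(=O)c1ccccc1`, gives 2000 nM. Compound 2, `O=C(O)CC/C=C\C[C@H]1[C@H](F)CC[C@@H]1NS(=O)(=O)c1ccccc1[N+](=O)[O-]`, gives 560 nM, the lowest of the three numbers; its nearest neighbour is compound 1, and the gap to compound 1 lies beyond the scatter, as does the gap to compound 3. The difference between the core of compound 2 and the core of compound 1 is not broken down here.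

Compound 1 and compound 3 differ in one place only: hydrogen in place of nitro on an aromatic carbon. That change produced a 1.1-fold higher number from compound 1 to compound 3 (0.02 log units; within the scatter), so the two numbers are treated as the same. The same change, at the same place, turns compound 2 into compound 4, `O=C(O)CC/C=C\C[C@H]1[C@H](F)CC[C@@H]1NS(=O)(=O)c1ccccc1`, which has not yet been measured in this assay: hydrogen in place of nitro on an aromatic carbon. Among the compounds considered here this change occurs twice, once measured and once not.

The expectation for compound 4 rests on that single earlier step and on nothing else. Because a 1.1-fold higher number from compound 1 to compound 3 (0.02 log units; within the scatter) lay within the scatter, the expected step is likewise small, a 1.1-fold higher number from compound 2 to compound 4 (0.04 log units; within the scatter). Compound 4 is accordingly estimated at 620 nM in this assay, with the number expected to fall between 280 nM and 1400 nM.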

Compound 4, half-maximal inhibitory concentration: 2000 nM
For compound 4 the middle estimate is 3.2-fold (0.51 log units) below the measured one; measured number outside the range, above it.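

In this assay, replacing nitro with hydrogen on the aromatic carbon, the change from 2-nitrophenyl to phenyl, gave a 3.6-fold higher number from compound 2 to compound 4 (0.55 log units; beyond the scatter), whereas the same change on the core of compound 1 had left the number unmoved. Among these compounds, the change therefore cannot be carried from one core to the other with its size intact, and the two steps are clearly different: the same change on two cores in this assay, a 1.1-fold higher number (0.02 log units; within the scatter) from compound 1 to compound 3 and a 3.6-fold higher number (0.55 log units; beyond the scatter) from compound 2 to compound 4, 3.4-fold (0.53 log units) apart, beyond the scatter of two such steps This shows that the nitro group counts on one core and not on the other, but with only two pairs it does not show what in the cores produces the difference, nor how the change would behave on any third core.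

The compounds shown leave open how an amine, a methoxy group or a chlorine atom in place of nitro on that aromatic carbon would read on either core. They also leave open which part of the difference between the two cores decides the size of the step, whether the fluorine on the core of compound 2 or the chain carrying the carboxylic acid, as no compound shown varies these one at a time.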